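The source may report more compounds than this note shows. Statements on the series, on what has been measured and on what is new or still open speak of the compounds shown alone.

Measured so far:
compound 1 `COc1ccc(N(CC(=O)NCCC[Te]c2ccccc2)C(=O)c2ccccc2)cc1` — 27000 nM
compound 2 `COc1ccc(N(CC(=O)NCCCSc2ccccc2)C(=O)CNC(=O)OC(C)(C)C)cc1` — >= 100000 nM

In a functional assay on MCF7 cells (Homo sapiens) for cytotoxicity, read by MTT assay, with a stated time of 24 h (on this read-out lower numbers stand for stronger inhibition and higher numbers for weaker inhibition), compound 1 gives 27000 nM. For compound 2 the assay reports only a limit, >= 100000 nM, and no number. Compound 2 therefore sits at the limit of >= 100000 nM in this assay, at which 1 of the 2 values shown sits, the weaker end of the two results shown, while compound 1 stands at a measured value.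

Compound 3 `COc1ccc(N(CC(=O)NCCCSc2ccccc2)C(=O)C#Cc2ccccc2)cc1` has not been measured in this assay. It differs from compound 2 by 2-phenylethynyl in place of ((tert-butoxycarbonyl)amino)methyl on a carbonyl carbon, so that the acyl group on the amide-type nitrogen now carries a phenyl ring, as the acyl group of compound 1 does. For the measured compounds named here, since no step between measured compounds is available, the size of the change must be estimated. The step from compound 2 to compound 3 is expected to be an at least 2.5-fold lower number from compound 2 to compound 3 (0.39 log units; beyond the scatter). This expectation is uncertain because compound 2 carries only the limit >= 100000 nM. Compound 3 is expected to give about 40000 nM, within 12000 nM to 130000 nM.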

Compound 3, half-maximal inhibitory concentration: >= 100000 nM
Compound 3 gave a limit, no number; the forecaster's own chance of this, stated with the estimate: 35%; middle value at least 2.5-fold (0.39 log units) away from the limit.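

Like compound 2, compound 3 has only a limit and no number in this assay, so no step from one to the other can be read: the limit of >= 100000 nM in this assay, at which 2 of the 3 values shown sit.

The compounds shown leave open how the 2-phenylethynyl and ((tert-butoxycarbonyl)amino)methyl groups compare in this assay.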